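The source may report more compounds than this note shows. Statements on the series, on what has been measured and on what is new or still open speak of the compounds shown alone.

Measured in an assay on isolated protein for displacement of a labelled ligand from melanin-concentrating hormone receptor 1 (Homo sapiens); on this read-out higher numbers stand for weaker inhibition and lower numbers for stronger inhibition:

Compound 1 `O=C(CCc1ccc(C(F)(F)F)cc1)Nc1ccc2nc(N3CCC(c4ccccc4)C3)ccc2c1` gives 25 nM.
Compound 2 `CCCc1cc(N(C)C)c2cc(NC(=O)CCc3ccc(C(F)(F)F)cc3)ccc2n1` gives 12 nM.

Compound 1 has the higher of the two numbers; compound 2 sits lower by a gap that is just beyond the usual scatter, so compound 2 reads as the somewhat stronger binder. Both share the same amide-linked trifluoromethylphenyl side chain and the same core, and they differ in what is attached to the core.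

The unmeasured compound 3 `CCN(CC)c1ccc2cc(NC(=O)CCc3ccc(C(F)(F)F)cc3)ccc2n1` is compound 1 with one substitution: diethylamino in place of 3-phenylpyrrolidin-1-yl on an aromatic carbon. The group that leaves carries a phenyl ring on a five-membered ring; the group that enters is a short open chain with no ring. Among the measured compounds shown here, no measured pair shows this exact exchange, so the expectation rests only on the size of what is removed. Losing a whole phenyl ring from that position is more likely to cost binding than to help it, and the step from compound 1 to compound 3 is expected to be a 2.8-fold higher number from compound 1 to compound 3 (0.45 log units; beyond the scatter), a moderate weakening beyond the scatter. In this assay compound 3 is estimated at 70 nM, with a likely range from 20 nM to 250 nM.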

Compound 3, half-maximal inhibitory concentration: 88 nM
For compound 3 the middle estimate is 1.3-fold (0.10 log units) below the measured one; measured number inside the range.
By their numbers in this assay, from the lowest: compound 2; then compound 1; then compound 3.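

In this assay, putting diethylamino in place of 3-phenylpyrrolidin-1-yl on the aromatic carbon next to the ring nitrogen gives a 3.5-fold higher number from compound 1 to compound 3 (0.55 log units; beyond the scatter) and lies beyond the usual scatter. Among the compounds shown here, compounds 1 and 2 differ in more than one place, so this is the first pair here that isolates this position: with everything else held the same, the group on this carbon changes the number, and the larger group with two rings goes with the stronger inhibition. The step is modest, however, and compound 3 gives 88 nM with neither ring present, so the rings are not required for a measurable value in this assay; no measurement at hand explains why the exchange has this effect.

The exchange removes both rings and several heavy atoms at once, so the contributions of the phenyl ring, the five-membered ring and overall size remain unseparated. A plain pyrrolidin-1-yl group would show what the five-membered ring does without the phenyl ring, while a dipropylamino group would show whether longer open chains on this carbon move the number back towards that of compound 1.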